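The source may report more compounds than this note shows. Statements on the series, on what has been measured and on what is new or still open speak of the compounds shown alone.

Measured so far in a functional assay on HL-60 cells (Homo sapiens) for antiproliferative activity, read by XTT assay, with a stated time of 72 h; a higher number here means a weaker inhibitor, a lower number a stronger inhibitor:

- compound 1 `COc1ncnc2c1c(-c1ccccc1)cn2[C@@H]1O[C@H](CO)[C@@H](O)[C@H]1O`: > 20000 nM
- compound 2 `CSc1ncnc2c1c(-c1ccsc1)cn2[C@@H]1O[C@H](CO)[C@@H](O)[C@H]1O`: 4590 nM

The entry for compound 1, > 20000 nM, is a limit of this assay and not a number. For the measured compounds named here, compound 2, at 4590 nM, therefore holds the only true number so far.

Compound 3 `CSc1ncnc2c1c(-c1ccccc1)cn2[C@@H]1O[C@H](CO)[C@@H](O)[C@H]1O` departs from compound 2 in one place: phenyl in place of thiophen-3-yl on an aromatic carbon, which is phenyl in place of thiophen-3-yl on an aromatic carbon. Going by the values given here, no measured pair isolates this change, so any forecast rests on thin evidence.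

Compound 1 also carries phenyl and reports > 20000 nM, a limit, so a modest shift towards weaker inhibition seems the better guess. The expected change in this assay is small, and the estimated step is a 2.2-fold higher number from compound 2 to compound 3 (0.34 log units; beyond the scatter).

For compound 3 the estimated value is 10000 nM, with an expected range of 3500 nM to 20000 nM.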

Compound 3, half-maximal inhibitory concentration: > 20000 nM
Compound 3: no number, only a limit; the forecaster's own chance of this, stated with the estimate: 30%; at least 2.0-fold (0.30 log units) between middle value and limit.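

In this assay, for the compounds shown here, this is the first pair that isolates the swap on this aromatic carbon, and it shows that the group here matters: phenyl in place of thiophen-3-yl gives an at least 4.3-fold higher number from compound 2 to compound 3 (0.63 log units; beyond the scatter), so only the thiophen-3-yl compound reaches a true number so far. From the compounds shown here alone, the real size of the step stays unknown, since the entry for compound 3 is a limit and not a number: the limit of > 20000 nM in this assay, at which 2 of the 3 values shown sit. The step between compound 1 and compound 3, methylsulfanyl in place of methoxy, cannot be read, as both entries are limits.

The compounds shown do not separate the sulfur of thiophen-3-yl from the size of its ring, and a furan-3-yl group at this place would bear on that. Going by these compounds, it also remains open whether the activity of compound 2 survives with methoxy or an amine in place of its methylsulfanyl group.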